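A methyl for a hydroxy in a weak compound

This account rests on a few compounds, and the source may have more. Where it says the series, first, only, none or still open, it means among the compounds named here.

Measured in a functional assay on NCI-H520 cells (Homo sapiens) for cytotoxicity; a lower number here means a stronger inhibitor of growth, a higher number a weaker inhibitor of growth:
Compound 1 `COc1ccc(C2=C(c3ccc(SC)cc3)CC3CCCN3C2=O)cc1O` gives 6000 nM as its value
Compound 2 `CSc1ccc(C2=C(c3ccc(O)c(O)c3)C(=O)N3CCCC3C2)cc1` gives 60000 nM as its value
Compound 3 `CSc1ccc(C2=C(c3ccc(O)cc3)C(=O)N3CCCC3C2)cc1` gives > 100000 nM as a limit, not a number

Compound 3 has only the limit > 100000 nM as its result in this assay and no measured number. In compound 4 `CSc1ccc(C2=C(c3ccc(C)cc3)C(=O)N3CCCC3C2)cc1` the change from compound 3 is methyl in place of hydroxy on an aromatic carbon, para to a large group.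

Among the compounds with values here, no measured step makes this exchange itself. The nearest evidence comes from changes on the same aryl group. There is a 10-fold higher number from compound 1 to compound 2 (1.00 log units; beyond the scatter) as one step and an at least 16-fold higher number from compound 1 to compound 3 (1.22 log units; beyond the scatter) as another, while an at least 1.6-fold higher number from compound 2 to compound 3 (0.22 log units; that floor lies within the scatter) has a floor within the scatter. All three point the same way, towards weaker growth inhibition, and none of them shows a route back. With an at least 16-fold higher number from compound 1 to compound 3 (1.22 log units; beyond the scatter) as the closest guide, nothing suggests a gain from the new methyl, so compound 4 is expected to remain close to the limit of compound 3. The expected step is an at least 1.2-fold lower number from compound 3 to compound 4 (0.09 log units; that floor lies within the scatter), which means none beyond the scatter in either direction. For compound 4 the estimated value is 80000 nM, with an expected range from 20000 nM to 200000 nM, and the result may well be only a limit.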

Compound 4, concentration for 50% growth inhibition: 900 nM
The estimate for compound 4 lay 89-fold (1.95 log units) above the measured number; the whole stated range lies above it.
By their numbers in this assay, from the lowest: compound 4; then compound 1; then compound 2. At a limit, above all of these: compound 3.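

In this assay, within the data shown here, the earlier compounds showed only losses as the oxygen groups on this aryl ring were altered, and none hinted that this position could give a strong inhibitor of growth. Putting a methyl in place of the hydroxy, para to a large group, reverses that picture, with a large gain (an at least 110-fold lower number from compound 3 to compound 4 (2.04 log units; beyond the scatter)), and the 4-methylphenyl group also outdoes both aryl groups that have measured numbers (a 67-fold lower number from compound 2 to compound 4 (1.82 log units; beyond the scatter); a 6.7-fold lower number from compound 1 to compound 4 (0.82 log units; beyond the scatter)), so oxygen on this ring is not needed for growth inhibition among these four compounds. The first of these steps gives only a floor, and its true size stays unknown, because compound 3 has a limit and not a number: the limit of > 100000 nM in this assay, at which 1 of the 4 values shown sits.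

Going by these compounds, what stays open is whether the gain comes from the new methyl itself or simply from the loss of the hydroxy, a question that an unsubstituted phenyl ring would help to settle. On these data alone, it is also open how far this position tolerates other groups, such as an ethyl, a chlorine or a methoxy alone in the same place.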